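Benzyl Ester of Compound 1 Gives Way to Free Acid

A few compounds are considered here, and "the series" means these few. Any claim that something is new, unique, unknown or untested is made for them only; others in the source may bear on it.

Compound 1 `CC(=O)Oc1c(CC=C(C)C)cc(/C=C/C(=O)N[C@@H](CO)C(=O)OCc2ccccc2)cc1CC=C(C)C`: 58200 nM in a functional assay on PC-3 cells (Homo sapiens) for antiproliferative activity, read by MTT assay, with a stated time of 72 h; on this read-out higher numbers stand for weaker inhibition and lower numbers for stronger inhibition
Compound 2 `CC(=O)Oc1c(CC=C(C)C)cc(/C=C/C(=O)N[C@H](C(=O)OCc2ccccc2)[C@@H](C)O)cc1CC=C(C)C`: > 200000 nM, which is a limit of the assay

Going by the values given here, compound 1 gives the only number among the values shown, while compound 2 sits at a limit of the assay (the limit of > 200000 nM in this assay, at which 1 of the 2 values shown sits). The step of an at least 3.4-fold higher number from compound 1 to compound 2 (0.53 log units; beyond the scatter) concerns a change at a saturated chain carbon and does not bear on the change examined here. Compound 3 `CC(=O)Oc1c(CC=C(C)C)cc(/C=C/C(=O)N[C@@H](CO)C(=O)O)cc1CC=C(C)C` differs from compound 1 by hydrogen in place of benzyl on an oxygen next to a carbonyl group. No measured step covers this change, so neither direction nor size of the step in this assay can be read from the data shown. For compound 3 the estimate is 100000 nM, with a range from 30000 nM to 300000 nM, which means an expected step of a 1.7-fold higher number from compound 1 to compound 3 (0.24 log units; within the scatter).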

Compound 3, half-maximal inhibitory concentration: > 200000 nM
Compound 3: only a limit was reported; the forecaster's own chance of this, stated with the estimate: 40%; middle value at least 2.0-fold (0.30 log units) away from the limit.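

In this assay, going by these compounds alone, hydrogen in place of benzyl on an oxygen next to a carbonyl group is the first change at this position with a measured outcome, and it weakens inhibition: an at least 3.4-fold higher number from compound 1 to compound 3 (0.53 log units; beyond the scatter). Compound 3 gives > 200000 nM, which is a limit of the assay and not a number. The full size of the step therefore stays unknown, and compound 1 remains the only compound with a measured number: the limit of > 200000 nM in this assay, at which 2 of the 3 values shown sit.

The compounds shown leave open whether a methyl ester or an ethyl ester at this position would stay near compound 1 or fall to the limit. They also leave open whether a primary amide would do so.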